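The source may hold more compounds than are shown below. What is called first, only, known or untested is meant among the compounds shown, and "the series" means these compounds.

Two compounds of the series carry a number in an assay on L cells for inhibition of Protein-serine O-palmitoleoyltransferase porcupine (Mus musculus), read by reporter gene assay, with a stated time of 24 h; on this read-out lower numbers stand for an effect already at smaller amounts and higher numbers for an effect only at larger amounts of compound. Compound 1 `O=C(CSc1nc2c(c(=O)n1-c1ccccc1)SCC2)Nc1nc2ccc(Cl)cc2s1` gives 40 nM in this assay. Compound 2 `O=C(CSc1nc2c(c(=O)n1-c1ccccc1)SCC2)Nc1ccc(-c2ccccn2)cc1` gives 4 nM in this assay, the lowest of the two numbers shown; the gap to compound 1 is beyond the scatter. Within the data shown here, no pair of measured compounds differs in a single place, so no measured step is available.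

Compound 3 `CCOc1ccc(NC(=O)CSc2nc3c(c(=O)n2-c2ccccc2)SCC3)cc1` has not yet been measured in this assay. It differs from compound 2 in one place: ethoxy in place of pyridin-2-yl on an aromatic carbon. Among the measured compounds shown here, the measured compounds give no example of exchanging the pyridin-2-yl group, and compound 1 carries a different amide partner altogether, so its number offers no direct guide to this change. Since compound 2 stands at the lowest number reached so far, the step is expected to run upward rather than downward, and is estimated at a 7.5-fold higher number from compound 2 to compound 3 (0.88 log units; beyond the scatter), beyond the scatter. Compound 3 is accordingly expected to give 30 nM in this assay, with a range from 8 nM to 120 nM.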

Compound 3, half-maximal effective concentration: 1000 nM
Compound 3: middle estimate off by 33-fold (1.52 log units), on the low side; measured number outside the range, above it.
By their numbers in this assay, from the lowest: compound 2; then compound 1; then compound 3.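

In this assay, the number depends strongly on the group on the aromatic carbon para to a large group: ethoxy in place of pyridin-2-yl gives a 250-fold higher number from compound 2 to compound 3 (2.40 log units; beyond the scatter), so this position does not accept this exchange without a large loss. The change on the amide-type nitrogen shows that the phenyl ring alone does not secure a low number: 4-ethoxyphenyl in place of 6-chloro-1,3-benzothiazol-2-yl gives a 25-fold higher number from compound 1 to compound 3 (1.40 log units; beyond the scatter), and the outcome depends on the group that ring carries. Nothing at hand gives a reason for either step.

As far as these compounds go, it remains open whether the low number of compound 2 depends on the ring of the pyridin-2-yl group or on its nitrogen, which a plain phenyl or a pyridin-3-yl group at this position would help separate. From the compounds shown here alone, it is also open whether the number of compound 3 follows the ether chain, as a methoxy group or a longer butoxy chain would show, or whether an amine or a carboxylic acid at this position would bring it down.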